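A few compounds are considered here, and "the series" means these few. Any claim that something is new, unique, unknown or untested is made for them only; others in the source may bear on it.

Measured compounds:
- compound 1 `C#CCOc1cc(O)c2c(c1)O[C@H](c1ccc(OC)c(O)c1)C/C2=N\O`: 19100 nM
- compound 2 `COc1ccc([C@@H]2CC(=O)c3c(O)cc(OCc4cn(Cc5ccccc5C#N)nn4)cc3O2)cc1O`: 14600 nM
- compound 3 `COc1ccc([C@@H]2C/C(=N\O)c3c(O)cc(OCc4cn(-c5ccccc5)nn4)cc3O2)cc1O`: 6130 nM

In a functional assay on RAW264.7 cells (Mus musculus) for inhibition, read by Griess assay, with stated times of 2 h and 24 h (a lower number here means a stronger inhibitor, a higher number a weaker inhibitor), compound 2 gives 14600 nM, the second highest of the three numbers. Its nearest neighbour is compound 1 at 19100 nM, a gap within the usual scatter, so no order between the two can be read; compound 3 at 6130 nM lies further off, beyond the scatter.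

The unmeasured compound 4 `COc1ccc([C@@H]2CC(=O)c3c(O)cc(OCc4cn(C5CCC5)nn4)cc3O2)cc1O` differs from compound 2 in one place: cyclobutyl in place of 2-cyanobenzyl on an aromatic nitrogen. For the measured compounds named here, the one step recorded so far, a 3.1-fold lower number from compound 1 to compound 3 (0.49 log units; beyond the scatter), concerns a different position, the group on the saturated chain carbon bound to an oxygen on the aromatic ring, together with a change elsewhere in the core, and does not bear on a swap of the group on the aromatic nitrogen of the five-membered aromatic ring with 3 nitrogen. Going by the values given here, no measured pair tells how such a swap moves this assay. The expectation is therefore no step beyond the scatter, a 1.0-fold lower number from compound 2 to compound 4 (0.02 log units; within the scatter), with wide uncertainty. Compound 4 is estimated at 14000 nM, range 5000 nM to 40000 nM.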

Compound 4, half-maximal inhibitory concentration: 15300 nM
Estimate against measurement, compound 4: 1.1-fold (0.04 log units) below; measured number inside the range.
By their numbers in this assay, from the lowest: compound 3; then compounds 2, 4 and 1 (each within the scatter of the next).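

In this assay, the group on the aromatic nitrogen of the five-membered aromatic ring with 3 nitrogen now has a pair that differs only there: cyclobutyl in place of 2-cyanobenzyl gives a 1.0-fold higher number from compound 2 to compound 4 (0.02 log units; within the scatter) and thus no readable change. In this pair, the six-membered aromatic ring of carbon only and the nitrile of 2-cyanobenzyl can be given up with no shift beyond the scatter. No measurement at hand accounts for this flat result.

Going by these compounds, one pair cannot show whether this position is generally tolerant, since an amine, a carboxylic acid or a longer alkyl chain on the same nitrogen remains open. Also open, on these data alone, is whether cyclobutyl and 2-cyanobenzyl would match each other with the oxime of compound 3 in place of the carbonyl.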